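A few compounds are considered here, and "the series" means these few. Any claim that something is new, unique, unknown or untested is made for them only; others in the source may bear on it.

Measured so far in a functional assay on U-87MG ATCC cells for antiproliferative activity against U-87 MG (Homo sapiens), read by MTT assay, with a stated time of 48 h, tested at 100 uM; a higher number here means a weaker effect of the compound at the concentration tested, a lower number a stronger effect:

compound 1, `COc1ccc(-c2nc(C)c(C(=O)CSc3nc(N)c(C#N)c(-c4ccc(Cl)cc4)n3)s2)cc1`: 3.9%
compound 2, `COc1ccc(-c2nc(C)c(C(=O)CSc3nc(-c4cccc(OC)c4)c(C#N)c(=O)[nH]3)s2)cc1`: 12.4%
compound 3, `COc1cccc(-c2nc(SCC(=O)c3sc(-c4ccccc4)nc3C)[nH]c(=O)c2C#N)c1`: 21.8%

Compound 1 stands lowest of the three numbers; compound 2 lies within the scatter of it, while compound 3 lies beyond it. Compounds 1 and 2 are built on different cores, and the difference between the two cores is not broken down here. From compound 2 to compound 3 the change is hydrogen in place of methoxy on an aromatic carbon, and it made a step of a number 9.4 percentage points higher from compound 2 to compound 3 (within the scatter).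

Compound 4, `Cc1nc(-c2ccccc2)sc1C(=O)CSc1nc(N)c(C#N)c(-c2ccc(Cl)cc2)n1`, is not yet measured. It differs from compound 1 by hydrogen in place of methoxy on an aromatic carbon, the same change at the same kind of place as that from compound 2 to compound 3. Resting on that single earlier step, the expected step from compound 1 to compound 4 is a number 6.1 percentage points higher from compound 1 to compound 4 (within the scatter), which would leave compound 4 still within the scatter of compound 1. The estimate for compound 4 in this assay is therefore 10%, between 2% and 24%.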

Compound 4, a percentage reported as activity, at one concentration (the size of the read-out at that concentration, not a potency): 17.1%
Compound 4: the middle estimate sits 7.1 percentage points below what was measured; measured number inside the range.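

In this assay, going from 4-methoxyphenyl to phenyl on the core of compound 1 gave a number 13.2 percentage points higher from compound 1 to compound 4 (beyond the scatter). Set beside the earlier step, the change does not differ measurably between the two cores: the same change on two cores in this assay, a number 9.4 percentage points higher (within the scatter) from compound 2 to compound 3 and a number 13.2 percentage points higher (beyond the scatter) from compound 1 to compound 4, 3.8 percentage points apart, within the scatter of two such steps The two steps are compatible with the change carrying over from one core to the other, but only one lies beyond the scatter, and two pairs can neither explain the steps nor show that the change would hold on a further core.

The compounds shown leave open what a hydroxyl, an amine or a fluorine in place of the methoxy would do. Each number gives the size of the effect at one concentration only, so they leave open how the effects would compare at any other concentration.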